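A few compounds are considered here, and "the series" means these few. Any claim that something is new, unique, unknown or untested is made for them only; others in the source may bear on it.

Compound 1 `COc1ccc(C=C(C(=O)/C=C/c2cccc(OC)c2OC)C(=O)/C=C/c2cccc(OC)c2OC)cc1OC`: 200 nM
Compound 2 `COc1cccc(/C=C/C(=O)C(=Cc2cc(OC)c(OC)c(OC)c2)C(=O)/C=C/c2cccc(OC)c2OC)c1OC`: 220 nM

Within the data shown here, in a functional assay on HepG2 cells (Homo sapiens) for antiproliferative activity, read by sulforhodamine B assay, with a stated time of 48 h (on this read-out lower numbers stand for stronger inhibition and higher numbers for weaker inhibition), compound 2, at 220 nM, cannot be separated from compound 1, the only other compound measured so far. Compound 3 `COc1cc(OC)c(C=C(C(=O)/C=C/c2cccc(OC)c2OC)C(=O)/C=C/c2cccc(OC)c2OC)c(OC)c1` has the same atoms as compound 2, joined differently: 2,4,6-trimethoxyphenyl in place of 3,4,5-trimethoxyphenyl on a double-bonded chain carbon bound to a double-bonded chain carbon. In words, 2,4,6-trimethoxyphenyl stands in place of 3,4,5-trimethoxyphenyl on a double-bonded chain carbon bound to a double-bonded chain carbon. Among the measured compounds shown here, only one measured step offers any guide: a 1.1-fold higher number from compound 1 to compound 2 (0.04 log units; within the scatter), where a methoxy replaced a hydrogen on an aromatic carbon. That step did not rearrange methoxy groups, so it bears on this change only loosely, and the data give no direction. No shift beyond the scatter is therefore expected in this assay. The expected step is a 1.1-fold higher number from compound 2 to compound 3 (0.04 log units; within the scatter). For compound 3 the estimate is 240 nM, with an expected range of 90 nM to 650 nM.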

Compound 3, half-maximal inhibitory concentration: 300 nM
Compound 3: the middle estimate sits 1.3-fold (0.10 log units) below what was measured, within the range that was stated.
By their numbers in this assay, from the lowest: compounds 1, 2 and 3 (each within the scatter of the next).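

In this assay, moving the methoxy groups from the 3,4,5-trimethoxyphenyl pattern to the 2,4,6-trimethoxyphenyl pattern gives a 1.4-fold higher number from compound 2 to compound 3 (0.13 log units; within the scatter) and so cannot be told apart from repeat-measurement noise. Setting 2,4,6-trimethoxyphenyl against 3,4-dimethoxyphenyl on the same double-bonded chain carbon gives a 1.5-fold higher number from compound 1 to compound 3 (0.18 log units; within the scatter), which is also no separable difference. The earlier pair covered only the addition of one methoxy, whereas these steps show that, among the three patterns tested here, the arrangement of the methoxy groups on this ring leaves the number within the scatter.

Nothing shown here explains why these three groups read alike. Also open is how a phenyl ring carrying an amine or a carboxylic acid would read at this place, as every compound shown carries only methoxy groups on that ring.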